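This account rests on a few compounds, and the source may have more. Where it says the series, first, only, none or still open, it means among the compounds named here.

Compound 1 `COc1nc(-c2ccccc2F)ccc1[C@@H](c1ccccc1)[C@@](O)(CCN(C)C)c1cccc2ccccc12`: in a toxicity assay on Vero cells (Chlorocebus sabaeus) for cytotoxicity (on this read-out higher numbers stand for lower toxicity in this test and lower numbers for higher toxicity in this test), compound 1 gives only the limit > 50 ug/mL, not a number.
Compound 2 `COc1nc(-c2cccc(F)c2)ccc1[C@@H](c1ccccc1)[C@@](O)(CCN(C)C)c1cccc2ccccc12`: in this assay compound 2 gives only the limit > 50 ug/mL, again not a number.

Compound 2 thus stands at the edge of what this assay reports, with a limit rather than a measured value. Among the measured compounds shown here, because compound 1 also returns a limit, the step that the two limits leave unreadable from compound 1 to compound 2 cannot be read; the only evidence on the measured step is the limit of > 50 ug/mL in this assay, at which 2 of the 2 values shown sit. Compound 3 `COc1nc(-c2ccccc2Cl)ccc1[C@@H](c1ccccc1)[C@@](O)(CCN(C)C)c1cccc2ccccc12` differs from compound 2 by 2-chlorophenyl in place of 3-fluorophenyl on an aromatic carbon. For the measured compounds named here, no measured step offers a readable size to carry over, and the one step available shows only that both compounds stayed at the limit. Compound 3 is therefore expected to remain at the limit as well, with an estimated value of 60 ug/mL and a range from 30 ug/mL to 150 ug/mL. The step that the limit leaves unreadable from compound 2 to compound 3 is expected to be none beyond the scatter.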

Compound 3, half-maximal cytotoxic concentration: > 50 ug/mL
Compound 3 gave a limit, no number; the forecaster's own chance of this, stated with the estimate: 80%; the middle value lies beyond the limit too.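

In this assay compound 3 gives only a limit, > 50 ug/mL and no number. Among the compounds shown here, no step among compound 1, compound 2 and compound 3 can be read: the limit of > 50 ug/mL in this assay, at which 3 of the 3 values shown sit. The compounds shown leave open how far apart these three lie, and what change on the shared core would bring a measurable value.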